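The compounds below may be only part of what the source reports. "The series", "measured", "known", "first", "only" and "open" are said of these compounds alone.

Compound 2 `CC(=O)NS(=O)(=O)c1ccc(-n2nc(-c3ccccc3)cc2-c2cc(O)ccc2O)cc1` shows the highest number of the three measured compounds in a functional assay on cells (Cancer cell lines, Homo sapiens) for cytotoxicity, read by sulforhodamine B assay, with a stated time of 48 h (on this read-out lower numbers stand for stronger inhibition of growth and higher numbers for weaker inhibition of growth), where compound 2 gives 100000 nM. Compound 1 `COc1ccc(OC)c(-c2cc(-c3ccccc3)nn2-c2ccc(S(=O)(=O)NC(C)=O)cc2)c1` gives 42600 nM, and compound 3 `CC(=O)NS(=O)(=O)c1ccc(-n2nc(-c3ccc(Cl)cc3)cc2-c2cc(O)ccc2O)cc1` gives 93900 nM. The change from compound 2 to compound 4 `CC(=O)NS(=O)(=O)c1ccc(-n2nc(-c3ccccc3)cc2C2=CC(=O)C=CC2=O)cc1` is a group of 8 heavy atoms (6 carbon, 2 oxygen; one six-membered non-aromatic ring of carbon only) in place of a group of 8 heavy atoms (6 carbon, 2 oxygen; one six-membered aromatic ring of carbon only), on an aromatic carbon. Neither measured step closely matches this change: a 2.3-fold higher number from compound 1 to compound 2 (0.37 log units; beyond the scatter), while a 1.1-fold lower number from compound 2 to compound 3 (0.03 log units; within the scatter). Going by the values given here, the only step that touches the same ring is the modest one from compound 1 to compound 2, so the expected step for compound 4 is uncertain; a modest move toward a lower number is expected, a 2.5-fold lower number from compound 2 to compound 4 (0.40 log units; beyond the scatter). Compound 4 is therefore expected to give about 40000 nM in this assay, with a likely range from 10000 nM to 120000 nM.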

Compound 4, concentration for total growth inhibition: 100000 nM
The estimate for compound 4 lay 2.5-fold (0.40 log units) below the measured number; the measured number falls inside the stated range.
By their numbers in this assay, from the lowest: compound 1; then compounds 3, 2 and 4 (each within the scatter of the next).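

At this position on the shared core, the ring with no aromatic character and no hydrogen-bond donors takes the place of 2,5-dihydroxyphenyl with no change at the digits printed from compound 2 to compound 4 (within the scatter) in this assay. Compared with the 2,5-dimethoxyphenyl group, the same ring gives a 2.3-fold higher number from compound 1 to compound 4 (0.37 log units; beyond the scatter), so among the groups tried here, only the 2,5-dimethoxyphenyl compound stands apart. No measurement given here explains this result. Still open, on these data alone, is how a phenyl ring carrying an amine or a carboxylic acid would behave at this position.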